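Alkynyl uracil series: tolerance on Vero cells, a first sweep

The compounds below may be only part of what the source reports. "The series", "measured", "known", "first", "only" and "open" are said of these compounds alone.

Measured so far, in an ADME assay on Vero cells (Chlorocebus sabaeus) for cytotoxicity, read by MTT assay; a lower number here means that less compound is tolerated, a higher number that more compound is tolerated:
- compound 1 `O=c1[nH]cc(C#CC2CCCCC2)c(=O)[nH]1` gives 247000 nM
- compound 2 `CCCCC#Cc1cn([C@@H]2O[C@H](CO)[C@@H](O)[C@H]2O)c(=O)[nH]c1=O` gives 103000 nM
- compound 3 `CCCCCCC#Cc1c[nH]c(=O)[nH]c1=O` gives 250000 nM

Compound 2 stands at the lowest of the three numbers in this assay, so it is the compound of which the least is tolerated here. Both compound 1 and compound 3 sit beyond the scatter above it, and those two stand within the scatter of each other, so no order can be read between them. Compound 2 is also the only one of the three that carries the sugar on the ring nitrogen; compound 1 and compound 3 have an unsubstituted ring nitrogen in its place. Among the measured compounds shown here, no pair among the measured compounds differs in a single place, so no step has been worked out yet.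

The next compound, compound 4 `O=c1[nH]c(=O)n([C@@H]2O[C@H](CO)[C@@H](O)[C@H]2O)cc1C#CC1CC1`, keeps the sugar of compound 2 and changes only the alkyne substituent:

cyclopropyl in place of butyl on a triple-bonded carbon

For the measured compounds named here, with no measured step to lean on, the expectation for compound 4 is a change of a 1.3-fold higher number from compound 2 to compound 4 (0.10 log units; within the scatter) in this assay, no larger than the scatter and if anything upward. Compound 4 is therefore expected to give 130000 nM, within a range of 60000 nM to 300000 nM.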

Compound 4, half-maximal cytotoxic concentration: 133000 nM
The estimate for compound 4 lay 1.0-fold (0.01 log units) below the measured number; low and high end bracket the measured number.
By their numbers in this assay, from the lowest: compounds 2, 4, 1 and 3 (each within the scatter of the next, the first and the last beyond it).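

In this assay, among the compounds shown here, the only pair so far that differs in one place gives a 1.3-fold higher number from compound 2 to compound 4 (0.11 log units; within the scatter) with the sugar kept, so this step stays within the scatter. On a triple-bonded carbon, an open butyl chain and a cyclopropyl group with its three-membered ring of carbon only therefore cannot be told apart by this read-out, even though the entering group has one heavy atom fewer and adds a ring. No measurement at hand bears on why this pair stands so close.

No pair among the compounds shown differs only in the sugar on the ring nitrogen, so the part of the sugar in these numbers stays open, and the one step read here says nothing about that place. Also open, going by these compounds, is whether a group of another kind on the triple-bonded carbon, such as an amine, a carboxylic acid or a chain longer than butyl, would move the number beyond the scatter with the sugar in place.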